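Two chloro groups on a shared core: a cytotoxicity estimate

A few compounds are considered here, and "the series" means these few. Any claim that something is new, unique, unknown or untested is made for them only; others in the source may bear on it.

Three compounds were measured in an ADME assay on MT4 cells (Homo sapiens) for cytotoxicity, read by MTT assay, with a stated time of 5 days; a higher number here means that more compound is tolerated, a lower number that less compound is tolerated. Compound 1 `COc1ccc2nc(Nn3c(-c4ccc([N+](=O)[O-])cc4)nnc3-c3cccnc3)sc2c1` gives 12.9 ug/mL. Compound 2 `O=[N+]([O-])c1ccc(-c2nnc(-c3cccnc3)n2Nc2nc3ccc(Cl)cc3s2)cc1` gives 53.7 ug/mL, and the change chloro in place of methoxy on an aromatic carbon made a step of a 4.2-fold higher number from compound 1 to compound 2 (0.62 log units; beyond the scatter). Compound 3 `COc1ccc2nc(Nn3c(-c4ccc(Cl)cc4)nnc3-c3cccnc3)sc2c1` gives 66.9 ug/mL; it differs from compound 1 by chloro in place of nitro on an aromatic carbon, a step of a 5.2-fold higher number from compound 1 to compound 3 (0.71 log units; beyond the scatter). Compound 4 `Clc1ccc(-c2nnc(-c3cccnc3)n2Nc2nc3ccc(Cl)cc3s2)cc1` is not yet measured. Compound 4 differs from compound 3 by chloro in place of methoxy on an aromatic carbon, the same change that separates compound 1 from compound 2, though on the core of compound 3 rather than that of compound 1. On the single earlier case, the step from compound 3 to compound 4 is expected to be a 2.2-fold higher number from compound 3 to compound 4 (0.35 log units; beyond the scatter), beside the step seen from compound 1 to compound 2. Compound 4 is therefore estimated at 150 ug/mL, between 60 ug/mL and 400 ug/mL, with the reminder that a single precedent carries little weight.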

Compound 4, half-maximal cytotoxic concentration: 54.3 ug/mL
The estimate for compound 4 lay 2.8-fold (0.44 log units) above the measured number; the measured number lies below the stated range.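

In this assay, among the compounds shown here, chloro in place of methoxy on an aromatic carbon gave a 1.2-fold lower number from compound 3 to compound 4 (0.09 log units; within the scatter), so the step did not carry over from one core to the other: the same change on two cores in this assay, a 4.2-fold higher number (0.62 log units; beyond the scatter) from compound 1 to compound 2 and a 1.2-fold lower number (0.09 log units; within the scatter) from compound 3 to compound 4, 5.1-fold (0.71 log units) apart, beyond the scatter of two such steps Chloro in place of nitro on an aromatic carbon gave a 1.0-fold higher number from compound 2 to compound 4 (0.00 log units; within the scatter), and this step did not carry over either: the same change on two cores in this assay, a 5.2-fold higher number (0.71 log units; beyond the scatter) from compound 1 to compound 3 and a 1.0-fold higher number (0.00 log units; within the scatter) from compound 2 to compound 4, 5.1-fold (0.71 log units) apart, beyond the scatter of two such steps Both larger steps start at compound 1, and with only two pairs for each change, the four compounds show that neither step can be assumed to transfer, but they do not show why.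

The compounds shown leave open how an amine or a carboxylic acid at these places would read in this assay. From the compounds shown here alone, whether either step would hold on a further core also remains open.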